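This account rests on a few compounds, and the source may have more. Where it says the series, first, only, none or still open, it means among the compounds named here.

Working notes on the series. All compounds share one core, differing only in the group on the saturated ring carbon. In an assay for inhibition of Tryptophan 2,3-dioxygenase (Homo sapiens), with a stated time of 1 h (on this read-out higher numbers stand for weaker inhibition and lower numbers for stronger inhibition), compound 1 `NS(=O)(=O)N1CCC(C(=O)/C(=N/O)Nc2ccc(F)c(Br)c2)CC1` gives 62500 nM. Compound 2 `O=C(/C(=N/O)Nc1ccc(F)c(Br)c1)C1CCCCC1`, the plain cyclohexyl analogue, gives 79300 nM in this assay; this stands as the higher of the two numbers reported, but the gap to compound 1 lies within the scatter, so the two read alike. Compound 3 `O=C(/C(=N/O)Nc1ccc(F)c(Br)c1)[C@H]1CC[C@H](NS(=O)(=O)Nc2ccccc2)CC1` reaches only a limit of the assay, > 100000 nM, which is a limit and not a number; note (the limit of > 100000 nM in this assay, at which 1 of the 3 values shown sits).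

Compound 4 `O=C(Nc1ccccc1)[C@H]1CC[C@H](C(=O)/C(=N/O)Nc2ccc(F)c(Br)c2)CC1` is the step from compound 2 under review: phenylcarbamoyl in place of hydrogen on a saturated ring carbon. Within the data shown here, no measured pair differing in one place exists in this set, so the step has no direct precedent. The expectation is a small shift toward weaker inhibition or none beyond the scatter, with a fair chance that only a limit is returned. Compound 4 is expected to give 90000 nM in this assay, with a range from 30000 nM to 300000 nM. The expected step is a 1.1-fold higher number from compound 2 to compound 4 (0.05 log units; within the scatter).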

Compound 4, half-maximal inhibitory concentration: > 100000 nM
Compound 4 gave a limit, no number; the forecaster's own chance of this, stated with the estimate: 50%; middle value at least 1.1-fold (0.04 log units) from the limit.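

Among these compounds, this is the first step that changes one place only, and it puts phenylcarbamoyl in place of hydrogen on a saturated ring carbon, three ring bonds from the ring atom that bears a large group. In this assay, on these data alone, the change gives an at least 1.2-fold higher number from compound 2 to compound 4 (0.10 log units; that floor lies within the scatter), so this group brings no stronger inhibition at this position, although the true size of the step stays unknown. Compound 4 stands at > 100000 nM, which is a limit and not a number, and the same limit recurs in the series: the limit of > 100000 nM in this assay, at which 2 of the 4 values shown sit.

As far as these compounds go, whether a small group on this ring carbon, such as an amine, a hydroxyl or a carboxylic acid, would move the number beyond the scatter remains open. From the compounds shown here alone, the direction of any such shift also remains open.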